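This account rests on a few compounds, and the source may have more. Where it says the series, first, only, none or still open, it means among the compounds named here.

Measured compounds in the series:

compound 1 `N=C(Nc1cccc(C(F)(F)F)c1)c1cc2c(-c3ccccc3)n[nH]c2cn1` — 24600 nM
compound 2 `Cn1nc(-c2ccccc2)c2cc(C(=N)Nc3ccccc3)ncc21` — 17400 nM
compound 3 `COc1ccc(Cn2nc(-c3ccccc3)c3cc(C(=N)Nc4ccccc4)ncc32)cc1` — 4700 nM

In a functional assay on HT-1080 cells (Homo sapiens) for cytotoxicity, read by MTT assay, with a stated time of 72 h (on this read-out higher numbers stand for weaker inhibition and lower numbers for stronger inhibition), compound 2 gives 17400 nM, the second highest of the three numbers. Compound 1 gives 24600 nM, a value within the scatter of compound 2, so the two are not distinguished. Compound 3 gives 4700 nM, and the step of a 3.7-fold lower number from compound 2 to compound 3 (0.57 log units; beyond the scatter) is the only one beyond the scatter; it concerns the substituent on the saturated chain carbon bound to the aromatic nitrogen, not the anilide ring.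

Compound 4 `Cn1nc(-c2ccccc2)c2cc(C(=N)Nc3cccc(C(F)(F)F)c3)ncc21` differs from compound 2 by trifluoromethyl in place of hydrogen on an aromatic carbon, placed meta to a large group on the six-membered carbon-only ring. Within the data shown here, no measured step isolates this change: compound 1 carries the same trifluoromethyl group but also differs from compound 2 at the ring nitrogen, so it bears only indirectly on the question. Given that compound 1 with 24600 nM sits within the scatter of compound 2, no step beyond the scatter is expected in this assay; the estimated step is a 1.1-fold higher number from compound 2 to compound 4 (0.06 log units; within the scatter). Compound 4 is therefore estimated at 20000 nM, with a range from 8000 nM to 50000 nM.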

Compound 4, half-maximal inhibitory concentration: 17800 nM
Beside the measured number, compound 4's estimate is 1.1-fold (0.05 log units) above it; low and high end bracket the measured number.
By their numbers in this assay, from the lowest: compound 3; then compounds 2, 4 and 1 (each within the scatter of the next).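

In this assay, trifluoromethyl in place of hydrogen on an aromatic carbon, meta to a large group, now has a step of its own: a 1.0-fold higher number from compound 2 to compound 4 (0.01 log units; within the scatter). This places the change on the six-membered aromatic ring of carbon only within the scatter, at least with the methyl group present on the aromatic nitrogen. Methyl in place of hydrogen on an aromatic nitrogen is also isolated, with trifluoromethyl present, as a 1.4-fold lower number from compound 1 to compound 4 (0.14 log units; within the scatter), and no measurement at hand offers an explanation for either result.

From the compounds shown here alone, whether an amine or a carboxylic acid at this place on the ring, or at other places on it, would give a step beyond the scatter remains open. Also open, going by these compounds, are whether a longer chain on the aromatic nitrogen would shift the number and whether the 4-methoxyphenyl step carries over to a compound bearing trifluoromethyl.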